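A few compounds are considered here, and "the series" means these few. Any claim that something is new, unique, unknown or untested is made for them only; others in the source may bear on it.

Of the compounds shown here, three have been measured in a functional assay on DU-145 cells (Homo sapiens) for inhibition, read by trypan blue exclusion, with a stated time of 96 h; on this read-out higher numbers stand for weaker inhibition of growth and lower numbers for stronger inhibition of growth. There, compound 1 `COc1ccccc1/C=C(\C(=O)c1ccc(Cl)cc1)S(=O)(=O)c1ccc(C)cc1` gives 1000 nM, compound 3 `COc1ccccc1/C=C(\C(=O)c1ccc([N+](=O)[O-])cc1)S(=O)(=O)Cc1ccc(Cl)cc1` gives 10000 nM, and compound 2 `COc1ccccc1/C=C(\C(=O)c1ccc(Cl)cc1)S(=O)(=O)Cc1ccc(Cl)cc1` gives 25000 nM, the highest of the three numbers. Compound 4 `CSc1ccc(/C=C(\C(=O)c2ccc(Cl)cc2)S(=O)(=O)Cc2ccc(Cl)cc2)cc1` departs from compound 2 at a single place: 4-(methylsulfanyl)phenyl in place of 2-methoxyphenyl on a double-bonded chain carbon bound to a double-bonded chain carbon. In words, 4-(methylsulfanyl)phenyl stands in place of 2-methoxyphenyl on a double-bonded chain carbon bound to a double-bonded chain carbon. Neither measured step touches that place. The change on the sulfonyl sulfur gave a 25-fold higher number from compound 1 to compound 2 (1.40 log units; beyond the scatter), a large step, and the change on an aromatic carbon gave a 2.5-fold lower number from compound 2 to compound 3 (0.40 log units; beyond the scatter), a modest one. These steps show that a single change can move the numbers in this assay, but they do not show what this exchange will do. With compound 2 at 25000 nM, the top of the numbers seen so far, a modest move toward a lower number is expected, though with wide uncertainty. The estimated change is a 2.1-fold lower number from compound 2 to compound 4 (0.32 log units; beyond the scatter). For compound 4 the expected value is 12000 nM, with an estimated range from 3000 nM to 40000 nM.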

Compound 4, concentration for 50% growth inhibition: 10000 nM
Compound 4: the middle estimate sits 1.2-fold (0.08 log units) above what was measured; the range from low to high includes it.
By their numbers in this assay, from the lowest: compound 1; then compounds 3 and 4 (each within the scatter of the next); then compound 2.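

In this assay, the step of a 2.5-fold lower number from compound 2 to compound 4 (0.40 log units; beyond the scatter) shows that the place on a double-bonded chain carbon bound to a double-bonded chain carbon also affects the number, which neither earlier step could show. The two groups have the same count of heavy atoms and each holds one six-membered aromatic ring, but sulfur enters for oxygen and the substituent's named location differs, so this single step cannot separate those two differences. No measured evidence bears on why the number moved.

The compounds shown leave open what a plain phenyl or a phenyl carrying a carboxylic acid would do at this place. They also leave open whether 4-(methylsulfanyl)phenyl would give a similar step in the presence of the 4-methylphenyl on the sulfonyl sulfur of compound 1.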